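The source may report more compounds than this note shows. Statements on the series, on what has been measured and on what is new or still open speak of the compounds shown alone.

In a functional assay on B16-F10 cells (Mus musculus) for antiproliferative activity, read by MTT assay, with a stated time of 48 h (on this read-out higher numbers stand for weaker inhibition and lower numbers for stronger inhibition), the measured compounds stand as follows, each value being a limit of the assay:

Compound 1 `COC1=CC(=O)N(C(=O)/C=C/[C@H](C)NC(=O)[C@H](CC(C)C)N(C)C)[C@H]1Cc1ccccc1` gives > 100000 nM as a limit
Compound 2 `COC1=CC(=O)N(C(=O)/C=C/[C@H](C)NC(=O)[C@H](CC(C)C)N(C)C)[C@@H]1Cc1ccccc1` gives > 100000 nM as a limit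
Compound 3 `CC[C@H](C)[C@H](NC(=O)OCc1ccccc1)C(=O)N[C@@H](CC(C)C)C(=O)N[C@@H](CC(C)C)C(=O)N[C@@H](C)/C=C/C(=O)N1C(=O)C=C(OC)[C@@H]1c1cn(C(=O)OC(C)(C)C)c2ccccc12` gives > 100000 nM as a limit

Compound 3 therefore has no number of its own, and its place cannot be ordered against the other two. The whole set shares one position, (the limit of > 100000 nM in this assay, at which 3 of the 3 values shown sit), so the data so far show no inhibition that can be given a size.

Compound 4 `CC[C@H](C)[C@H](NC(=O)OCc1ccccc1)C(=O)N[C@@H](CC(C)C)C(=O)N[C@@H](CC(C)C)C(=O)N[C@@H](C)/C=C/C(=O)N1C(=O)C=C(OC)[C@@H]1c1c[nH]c2ccccc12` differs from compound 3 in one place: hydrogen in place of tert-butoxycarbonyl on an aromatic nitrogen. This puts hydrogen in place of tert-butoxycarbonyl on an aromatic nitrogen.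

Among the measured compounds shown here, only one measured step exists, a step that the two limits leave unreadable from compound 1 to compound 2. It concerns the fact that compounds 1 and 2 differ only in the configuration as drawn and not this nitrogen, so it offers no size to carry over. With no readable step to go on, the expectation in this assay is modest: if any change appears, it should run towards stronger inhibition, but a result that stays at the limit remains the likelier outcome, given that compound 3 sits at > 100000 nM. The expected move is an at least 1.2-fold lower number from compound 3 to compound 4 (0.09 log units; that floor lies within the scatter). The estimated value for compound 4 is 80000 nM (expected range 15000 nM to 200000 nM) .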

Compound 4, half-maximal inhibitory concentration: > 100000 nM
Compound 4 was reported as a limit (the forecaster's own chance of this, stated with the estimate: 60%); middle value at least 1.2-fold (0.09 log units) away from the limit.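

In this assay, among the compounds shown here, the step between compound 3 and compound 4 cannot be read, since both values are limits of the assay, so no new step comes from this result. The compounds shown leave open whether hydrogen in place of tert-butoxycarbonyl on the aromatic nitrogen changes inhibition at all, because no value yet has a size: the limit of > 100000 nM in this assay, at which 4 of the 4 values shown sit.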